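The source may hold more compounds than are shown below. What is called first, only, known or untested is meant among the compounds shown, and "the series" means these compounds.

In a functional assay on HCT-116 cells (Homo sapiens) for antiproliferative activity, read by MTT assay, with a stated time of 72 h (on this read-out lower numbers stand for stronger inhibition of growth and higher numbers for weaker inhibition of growth), compound 3 `Cn1nc(-c2ccnc(Nc3cccc(O)c3)n2)c2ccccc21` gives 17200 nM, the second highest of the three numbers measured. Compound 2 `Cn1nc(-c2ccnc(Nc3ccc(O)cc3)n2)c2ccccc21` gives 8430 nM, while compound 1 `c1ccc(Cn2c(Nc3ccccc3)nc3cccnc32)cc1` gives 60200 nM. Among the measured compounds shown here, the one recorded step, a 2.0-fold higher number from compound 2 to compound 3 (0.31 log units; beyond the scatter), arose from moving the hydroxyl within the phenyl group. Compound 4 `Cc1ccc(Nc2nccc(-c3nn(C)c4ccccc34)n2)cc1` differs from compound 3 by 4-methylphenyl in place of 3-hydroxyphenyl on a nitrogen on an aromatic ring. For the measured compounds named here, no measured pair exchanges a hydroxyphenyl for a methylphenyl, so the step from compound 2 to compound 3 is only a loose guide, showing that altering this substituent shifted the number modestly. The expected step is a 1.1-fold lower number from compound 3 to compound 4 (0.06 log units; within the scatter), small in either direction. Compound 4 is accordingly estimated in this assay at 15000 nM, with a range from 5000 nM to 45000 nM.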

Compound 4, concentration for 50% growth inhibition: 8640 nM
For compound 4 the middle estimate is 1.7-fold (0.24 log units) above the measured one, and the stated range covers the measured number.
By their numbers in this assay, from the lowest: compounds 2, 4 and 3 (each within the scatter of the next, the first and the last beyond it); then compound 1.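

In this assay, among the compounds shown here, the exchange of hydroxy for methyl on an aromatic carbon gives a 1.0-fold higher number from compound 2 to compound 4 (0.01 log units; within the scatter), a direct comparison the earlier compounds lacked, so the 4-methylphenyl group, with 0 hydrogen-bond donors, stands within the scatter of the 4-hydroxyphenyl group. The exchange of 3-hydroxyphenyl for 4-methylphenyl gives a 2.0-fold lower number from compound 3 to compound 4 (0.30 log units; within the scatter), which also stays within the scatter, although the step between the two hydroxyphenyl compounds lies beyond it. No measurement at hand offers a reason for these results. The compounds shown leave open how methoxy, an amine or a carboxylic acid on that aromatic carbon would read in this assay.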